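A few compounds are considered here, and "the series" means these few. Any claim that something is new, unique, unknown or untested is made for them only; others in the source may bear on it.

Measured in an ADME assay on Vero cells (Chlorocebus sabaeus) for cytotoxicity, read by resazurin assay, with a stated time of 72 h; on this read-out lower numbers stand for stronger inhibition and higher numbers for weaker inhibition:
- compound 1 `O=C(CCN1CCN(c2ccc(Cl)cc2)CC1)c1ccc(F)c(Br)c1`: 206000 nM
- compound 2 `O=C(CCN1CCN(c2ccc(Cl)cc2)CC1)c1ccc(F)c(F)c1`: 86200 nM
- compound 3 `O=C(CCN1CCN(c2ccc(F)cc2)CC1)c1ccc(F)c(Cl)c1`: 185000 nM

In this assay, compound 3 gives 185000 nM. That value lies within the scatter of compound 1 and beyond the scatter above compound 2.

Compound 4 `O=C(CCN1CCN(c2ccc(Cl)cc2)CC1)c1ccc(F)c(Cl)c1` follows from compound 3 by one change, chloro in place of fluoro on an aromatic carbon, or 4-fluorophenyl to 4-chlorophenyl. Among the measured compounds shown here, no measured step covers this exact swap. The nearest evidence is a 2.4-fold lower number from compound 1 to compound 2 (0.38 log units; beyond the scatter), a modest step with fluoro in place of bromo at another place in the molecule. Compound 4 shares the 4-chlorophenyl group of compound 1 and compound 2, and it carries chloro where they carry bromo and fluoro. Its value is therefore expected to fall between theirs, so only a small downward move from compound 3 is anticipated, probably within the scatter. The estimated step is a 1.4-fold lower number from compound 3 to compound 4 (0.15 log units; within the scatter). Compound 4 is estimated at 130000 nM, with an expected range of 75000 nM to 220000 nM.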

Compound 4, half-maximal inhibitory concentration: 114000 nM
The estimate for compound 4 lay 1.1-fold (0.06 log units) above the measured number; measured number inside the range.
By their numbers in this assay, from the lowest: compounds 2, 4, 3 and 1 (each within the scatter of the next, the first and the last beyond it).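

In this assay, among the compounds shown here, the change from 4-fluorophenyl to 4-chlorophenyl gives a 1.6-fold lower number from compound 3 to compound 4 (0.21 log units; within the scatter) and so offers the first reading at this position, para to a large group, where the swap of fluoro for chloro stays inside the usual scatter. At the other halogen place, chloro in place of fluoro gives a 1.3-fold higher number from compound 2 to compound 4 (0.12 log units; within the scatter) and chloro in place of bromo gives a 1.8-fold lower number from compound 1 to compound 4 (0.26 log units; within the scatter) as well. The earlier step of a 2.4-fold lower number from compound 1 to compound 2 (0.38 log units; beyond the scatter) therefore resolves into two smaller steps through compound 4, neither of them beyond the scatter. The compounds shown leave open how bromo, a methoxy group or an amine would read at the para position of this phenyl group. No measurement at hand offers an explanation for any of these steps.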